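Shrinking the Amide Ring from Cyclohexyl to Cyclopentyl

The compounds below may be only part of what the source reports. "The series", "measured", "known", "first", "only" and "open" are said of these compounds alone.

Compound 1 `Nc1sc(-c2ccc(Cl)cc2)c(-c2ccc(Cl)cc2)c1C(=O)NC1CCCCC1` gives the lowest number of the three measured compounds in a functional assay on A549 cells (Homo sapiens) for inhibition, read by sulforhodamine B assay, with a stated time of 72 h (a lower number here means a stronger inhibitor, a higher number a weaker inhibitor), at 2410 nM. Compound 3 `Nc1sc(-c2ccc(Cl)cc2)c(-c2ccc(Cl)cc2)c1C(=O)N1CCC(=O)CC1=O` gives 4090 nM, and the step between them is a 1.7-fold higher number from compound 1 to compound 3 (0.23 log units; within the scatter). Compound 2 `Nc1sc(-c2ccc(Cl)cc2)c(-c2ccc(Cl)cc2)c1C(=O)NC1CCC1` gives 12500 nM; the step of a 5.2-fold higher number from compound 1 to compound 2 (0.71 log units; beyond the scatter) accompanies the change to cyclobutyl. Compound 4 `Nc1sc(-c2ccc(Cl)cc2)c(-c2ccc(Cl)cc2)c1C(=O)NC1CCCC1` differs from compound 1 by cyclopentyl in place of cyclohexyl on an amide-type nitrogen. Within the data shown here, only the step from compound 1 to compound 2 bears on this change, and a five-membered ring lies between the six-membered cyclohexyl and the cyclobutyl of compound 2; since that step was a 5.2-fold higher number from compound 1 to compound 2 (0.71 log units; beyond the scatter), a smaller upward step is expected here, a 1.9-fold higher number from compound 1 to compound 4 (0.27 log units; within the scatter). Compound 4 is therefore estimated at 4500 nM, within a range from 2200 nM to 10000 nM.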

Compound 4, half-maximal inhibitory concentration: 6790 nM
The estimate for compound 4 lay 1.5-fold (0.18 log units) below the measured number, and the stated range covers the measured number.
By their numbers in this assay, from the lowest: compounds 1, 3, 4 and 2 (each within the scatter of the next, the first and the last beyond it).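

In this assay, taking one carbon out of the cyclohexyl ring is already enough for a step beyond the scatter (a 2.8-fold higher number from compound 1 to compound 4 (0.45 log units; beyond the scatter)), so the six-membered ring is not interchangeable with the five-membered one at this amide-type nitrogen. The data do not separate cyclopentyl from cyclobutyl (a 1.8-fold lower number from compound 2 to compound 4 (0.27 log units; within the scatter)) or cyclopentylamino from 2,4-dioxopiperidin-1-yl (a 1.7-fold higher number from compound 3 to compound 4 (0.22 log units; within the scatter)). No measurement available here explains the difference between the two ring sizes.

Going by these compounds, whether a larger ring such as cycloheptyl would match or beat cyclohexyl remains open. So does the effect of an open chain such as hexyl, or of a ring carrying an amine, on this nitrogen.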